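Lactone Amine in Place of a Carboxylic Acid Side Chain

A few compounds are considered here, and "the series" means these few. Any claim that something is new, unique, unknown or untested is made for them only; others in the source may bear on it.

Measured compounds:
Compound 1, `CC[C@@H](Nc1c(C#N)c(-c2ccc(-c3ccccc3F)cc2)nc2cnccc12)C(N)=O`: 2.7
Compound 2, `CCOc1ccccc1-c1ccc(-c2nc3cnccc3c(C[C@H](C)C(=O)O)c2C#N)cc1`: 2.2

The account follows the step from compound 2 to compound 3, `CCOc1ccccc1-c1ccc(-c2nc3cnccc3c(N[C@@H]3CCOC3=O)c2C#N)cc1`, which has not yet been measured. Going by the values given here, in a physicochemical assay for lipophilicity, read by HPLC, at pH 7.5 (on this read-out higher numbers stand for higher lipophilicity and lower numbers for lower lipophilicity), compound 2 gives 2.2, the lowest of the two numbers known so far. Its nearest neighbour is compound 1, which in this assay gives 2.7, a higher number, and the gap between the two lies beyond the scatter of the measurement. Among the compounds with values here, no single-point step between the two measured compounds exists, as they differ in more than one place, so only their two values can be compared.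

Compound 3 differs from compound 2 in one place: (2-oxooxolan-3-yl)amino in place of 2-carboxypropyl on an aromatic carbon. The group that leaves carries a carboxylic acid; the group that enters is a ring-closed ester attached through an amino link, with one more acceptor and no acid. On this basis the step from compound 2 to compound 3 is expected to run upward and to exceed the usual scatter, estimated as a number 1.00 log units higher from compound 2 to compound 3 (beyond the scatter). Compound 3 is accordingly estimated at 3.2, in the range 2.6 to 3.8.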

Compound 3, distribution coefficient: 2.7
Beside the measured number, compound 3's estimate is 0.50 log units above it; low and high end bracket the measured number.
By their numbers in this assay, from the lowest: compound 2; then compounds 1 and 3 (each within the scatter of the next).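

At this position, on an aromatic carbon opposite the ring nitrogen and ortho to a cyano group, replacing 2-carboxypropyl with (2-oxooxolan-3-yl)amino gives, in this assay, a number 0.50 log units higher from compound 2 to compound 3 (beyond the scatter). This is the only single-place step shown, and it gives the first direct reading of a change at this position, which the two earlier compounds, differing in more than one place, could not provide. The number moved upward as the substituent gained a five-membered non-aromatic ring and went from 1 to 3 hydrogen-bond acceptors, with 1 hydrogen-bond donor on each side, but nothing shown bears on why the number rose.

The compounds shown leave open which part of the change accounts for the step: the amino link, the closed ring or the removal of the carboxylic acid. An open-chain ethyl ester on the same amino link, or an amino-linked carboxylic acid, would separate these parts, and a lactam in place of the lactone would test the ring oxygen.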